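The compounds below may be only part of what the source reports. "The series", "measured", "known", "first", "only" and "open" are said of these compounds alone.

Measured so far:

Compound 1, `CCC/C=C/C(=O)N(Cc1ccc(OC)c(O)c1)c1cc(OC)c(OC)c(OC)c1`, gives 57 nM.
Compound 2, `C/C=C/C(=O)N(Cc1cc(OC)c(OC)c(OC)c1)c1ccc(OC)c(O)c1`, gives 9160 nM.
Compound 3, `COc1ccc(CNc2cc(OC)c(OC)c(OC)c2)cc1C`, gives 73800 nM.

All three were tested in a functional assay on KYSE-450 cells (Homo sapiens) for inhibition, read by MTT assay, with a stated time of 48 h; a higher number here means a weaker inhibitor, a lower number a stronger inhibitor. Compound 1 stands at the lowest number of the three, and both gaps to the others are beyond the usual scatter: compound 2 sits far higher, and compound 3 higher still. Compound 1 is therefore the strongest inhibitor among the measured compounds, and it is the starting point for the new compound.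

Compound 4, `C/C=C/C=C/C(=O)N(Cc1ccc(OC)c(O)c1)c1cc(OC)c(OC)c(OC)c1`, keeps the whole of compound 1 except for one spot on the chain that carries the carbonyl. The change is prop-1-en-1-yl in place of propyl on a double-bonded chain carbon bound to a double-bonded chain carbon. The amide, both aromatic rings and their substituents are untouched; only the outer part of the chain gains a second double bond, so that the chain becomes fully conjugated from the carbonyl outward.

Among the measured compounds shown here, no measured pair shows the effect of exactly this change, so the expectation rests on compound 1 alone. Since the groups that set compound 1 apart from compound 2 and compound 3 all stay in place, the step of a 1.4-fold higher number from compound 1 to compound 4 (0.15 log units; within the scatter) is expected to be small, probably within the scatter. Compound 4 is thus estimated at 80 nM, with a likely range from 20 nM to 320 nM.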

Compound 4, half-maximal inhibitory concentration: 180 nM
Estimate against measurement, compound 4: 2.3-fold (0.35 log units) below, within the range that was stated.
By their numbers in this assay, from the lowest: compound 1; then compound 4; then compound 2; then compound 3.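

In this assay, putting prop-1-en-1-yl in place of propyl on a double-bonded chain carbon bound to a double-bonded chain carbon gives a 3.2-fold higher number from compound 1 to compound 4 (0.50 log units; beyond the scatter), a modest step but one that lies beyond the scatter. Among the compounds shown here, this is the first direct reading at this spot on the chain, and it shows that the spot responds to a small edit: the entering and leaving groups have the same number of heavy atoms, and the outer part of the chain differs only by a double bond. The change weakens compound 1 without abolishing its activity, as compound 4 still gives 180 nM in this assay, but no supporting measurement is available to explain the step.

A single pair cannot show whether this weakening is specific to the added double bond or whether other groups at this spot, such as a longer chain like pentyl or a phenyl ring, would be tolerated equally well or better. From the compounds shown here alone, it also remains open whether the same order of compound 1 and compound 4 would hold on other cell types or with other exposure times.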